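The source may hold more compounds than are shown below. What is called first, only, known or untested is meant among the compounds shown, and "the series" means these compounds.

Of the compounds shown here, two have so far been measured in a functional assay on HeLa cells (Homo sapiens) for cytotoxicity, read by MTT assay, with a stated time of 72 h, tested at 3 uM; on this read-out lower numbers stand for less inhibition of growth and higher numbers for more inhibition of growth at the one concentration tested. Compound 1 `Cc1ccnc(/C(N)=N/NC(=S)N2CCOCC2)c1` gives 44.7%. Compound 2 `Cc1ccnc(/C(N)=N/NC(=S)N2CCN(c3ccccn3)CC2)c1` gives 42.5%, a number that lies within the scatter of the value for compound 1, so the two compounds cannot be told apart on this read-out. Compound 3 `N/C(=N\NC(=S)N1CCN(c2ccccn2)CC1)c1ccccn1` has not yet been measured. It differs from compound 2 by hydrogen in place of methyl on an aromatic carbon, so that the 4-methylpyridin-2-yl becomes pyridin-2-yl. Among the compounds with values here, no measured step of this kind exists in the set, and only a small shift, or none beyond the scatter, is expected, corresponding to a number 2.5 percentage points lower from compound 2 to compound 3 (within the scatter). Compound 3 is therefore estimated at 40%, between 25% and 55%.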

Compound 3, percent growth inhibition at one concentration: 24.4%
Estimate against measurement, compound 3: 15.6 percentage points above, outside the stated range (below it).
By their numbers in this assay, from the lowest: compound 3; then compounds 2 and 1 (each within the scatter of the next).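

In this assay, the aromatic carbon opposite the ring nitrogen proves to be a position that counts: hydrogen in place of methyl gives a number 18.1 percentage points lower from compound 2 to compound 3 (beyond the scatter), so compound 2 with its 4-methylpyridin-2-yl keeps more growth inhibition than compound 3 with its pyridin-2-yl. The earlier compounds shown here offered no step at this position. Nothing available explains this difference.

As far as these compounds go, whether an ethyl, a methoxy or a chlorine at the same carbon would match the methyl remains open. So does whether the same change would have a similar effect in compound 1.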